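Methyl for phenyl on the saturated ring: compounds 2 and 4

A few compounds are considered here, and "the series" means these few. Any claim that something is new, unique, unknown or untested is made for them only; others in the source may bear on it.

Compound 1 `CC1CCN(C(=O)CCNC(=O)c2ccc(S(C)(=O)=O)c([N+](=O)[O-])c2)CC1` gives > 60000 nM in an assay on isolated protein for inhibition of thyroid hormone receptor alpha (Homo sapiens), read by fluorescence polarization (on this read-out lower numbers stand for stronger inhibition and higher numbers for weaker inhibition), which is a limit of the assay and not a number.
Compound 2 `CS(=O)(=O)c1ccc(C(=O)NCCCC(=O)N2CCC(c3ccccc3)CC2)cc1[N+](=O)[O-]` gives > 60000 nM in this assay, again a limit of the assay.
Compound 3 `CN(Cc1ccccc1F)C(=O)CNC(=O)c1ccc(S(C)(=O)=O)c([N+](=O)[O-])c1` gives > 60000 nM in this assay, likewise a limit of the assay.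

Compound 2 therefore stands at the limit, and it does not stand apart from the rest of the series: the limit of > 60000 nM in this assay, at which 3 of the 3 values shown sit. For the measured compounds named here, no compound in the set has a numeric reading, so no measured step between any two of them is available, and no pattern of potency can be drawn from the three.

Compound 4 `CC1CCN(C(=O)CCCNC(=O)c2ccc(S(C)(=O)=O)c([N+](=O)[O-])c2)CC1` is the one still to be measured. It differs from compound 2 at the saturated ring carbon of the six-membered non-aromatic ring with 1 nitrogen: methyl in place of phenyl on a saturated ring carbon. Compound 1 already carries a methyl at that ring position, with a shorter chain, and sits at the limit.

With every reading in the series at the limit, the change from compound 2 to compound 4 is expected to move nothing beyond the scatter, and the expected step is a step that the limit leaves unreadable from compound 2 to compound 4. Compound 4 is therefore expected to give about 100000 nM, within 30000 nM to 300000 nM, and most likely to be reported as a limit again rather than as a number.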

Compound 4, half-maximal inhibitory concentration: > 60000 nM
Compound 4: only a limit was reported (the forecaster's own chance of this, stated with the estimate: 90%); the middle value lies beyond the limit too.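

No new step can be read: compound 2 and compound 4 are both reported only as limits in this assay, so the effect of methyl in place of phenyl on a saturated ring carbon stays unreadable. The compounds shown leave open what structure on this shared core would give a numeric reading, since the series rests entirely at: the limit of > 60000 nM in this assay, at which 4 of the 4 values shown sit.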